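The source may report more compounds than this note shows. Statements on the series, on what has been measured and on what is new or still open speak of the compounds shown alone.

Protein binding notes on the series. In an ADME assay on the whole organism (plasma, Rattus norvegicus) for protein binding, using cassette dosing, at a dose of 1 mg/kg (on this read-out higher numbers stand for a larger free fraction and lower numbers for a smaller free fraction), compound 1 `Cc1ccc(Cn2c(=O)n(C[C@H](C)C(=O)O)c(=O)[nH]/c2=N\c2ccc(OC(C)C)c(Cl)c2)cc1` gives 0.014, compound 2 `CC(C)Oc1ccc(/N=c2\[nH]c(=O)n(C[C@@H](O)CO)c(=O)n2Cc2ccc(Cl)cc2)cc1Cl` gives 0.001, and compound 3 `C[C@@H](Cn1c(=O)[nH]/c(=N\c2ccc(Oc3cccc(F)n3)cc2)n(Cc2ccc(Cl)cc2)c1=O)C(=O)O` gives 0.007. Compound 3 stands second highest of the three numbers: its value and that of compound 1 lie within the scatter of each other, while the value of compound 2 sits lower by a gap beyond the scatter. Compound 4 `C[C@@H](Cn1c(=O)[nH]/c(=N\c2ccc(Oc3cnccn3)cc2)n(Cc2ccc(Cl)cc2)c1=O)C(=O)O` has not yet been measured in this assay. It differs from compound 3 by pyrazin-2-yl in place of 6-fluoropyridin-2-yl on an oxygen on an aromatic ring. Among the measured compounds shown here, no measured pair isolates this change, so the expected step from compound 3 to compound 4, a 1.4-fold higher number from compound 3 to compound 4 (0.15 log units; within the scatter), is small and upward, not beyond the scatter. Compound 4 is estimated at 0.01, with a range from 0.004 to 0.025.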

Compound 4, unbound fraction: 0.018
Compound 4: the middle estimate sits 1.8-fold (0.26 log units) below what was measured, within the range that was stated.
By their numbers in this assay, from the lowest: compound 2; then compounds 3, 1 and 4 (each within the scatter of the next, the first and the last beyond it).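

In this assay, the series gains its first comparison that differs in one place: pyrazin-2-yl in place of 6-fluoropyridin-2-yl gives a 2.6-fold higher number from compound 3 to compound 4 (0.41 log units; beyond the scatter), a modest step. Among the compounds shown here, the ring on this oxygen therefore affects the free fraction, which the earlier compounds could not isolate. Nothing available explains the step.

The compounds shown do not separate the loss of fluorine from the added ring nitrogen; a plain pyridin-2-yl on the same oxygen would do so. From the compounds shown here alone, whether the step carries over to other groups on the core remains open.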